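A few compounds are considered here, and "the series" means these few. Any claim that something is new, unique, unknown or untested is made for them only; others in the source may bear on it.

Compound 1 `COc1ccc(-c2nc(C(=O)/C=C\Nc3ccc(F)cc3)c3ccccn23)cc1`, compound 2 `COc1ccc(N/C=C\C(=O)c2nc(-c3ccccc3)n3ccccc23)cc1` and compound 3 `COc1ccc(-c2nc(C(=O)/C=C\Nc3ccc4[nH]ccc4c3)c3ccccn23)cc1` share one core and differ only in the group on the amine nitrogen and the group on the core. In a functional assay on MDA-MB-231 cells (Homo sapiens) for cytotoxicity, read by MTT assay, with a stated time of 48 h (a higher number here means a weaker inhibitor, a lower number a stronger inhibitor), compound 1 gives only a limit, > 30000 nM. Compound 2 gives 28300 nM in this assay. Compound 3 gives 28700 nM in this assay, and the gap between compound 3 and compound 2 lies within the scatter, so the two cannot be ranked. Among the compounds with values here, the one measured step, an at least 1.0-fold lower number from compound 1 to compound 3 (0.01 log units; that floor lies within the scatter), starts from a limit, as the limit of > 30000 nM in this assay, at which 1 of the 3 values shown sits, shows, and its floor lies within the scatter, so no step so far establishes any change in the number beyond the scatter.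

Compound 4, `COc1ccc(N/C=C\C(=O)c2nc(-c3ccc(OC)cc3)n3ccccc23)cc1`, is not yet measured. It differs from compound 3 in one place: 4-methoxyphenyl in place of 1H-indol-5-yl on an amine nitrogen. Within the data shown here, no measured step bears directly on this change; the only step known, an at least 1.0-fold lower number from compound 1 to compound 3 (0.01 log units; that floor lies within the scatter), concerns the same nitrogen and did not exceed the scatter. Compound 2 already carries 4-methoxyphenyl on the amine nitrogen and gives 28300 nM, close to compound 3. For compound 4 the expected step, resting on compound 2 at 28300 nM, is a 1.0-fold higher number from compound 3 to compound 4 (0.02 log units; within the scatter), none beyond the scatter. Compound 4 is expected to give 30000 nM in this assay, between 15000 nM and 60000 nM, with a real chance that only a limit is reported.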

Compound 4, half-maximal inhibitory concentration: > 30000 nM
Compound 4 ended at the assay's limit; the forecaster's own chance of this, stated with the estimate: 45%; the middle value lies on the limit itself.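

Methoxy in place of hydrogen on an aromatic carbon is a change the earlier compounds did not test, and it gives an at least 1.0-fold higher number from compound 2 to compound 4 (0.02 log units; that floor lies within the scatter), so this position shows no change beyond the scatter so far. On the amine nitrogen, 4-methoxyphenyl in place of 1H-indol-5-yl gives an at least 1.0-fold higher number from compound 3 to compound 4 (0.01 log units; that floor lies within the scatter), so the second change at this nitrogen also establishes no difference, although 1H-indol-5-yl carries a hydrogen-bond donor and 4-methoxyphenyl a hydrogen-bond acceptor. The step between compound 1 and compound 4 cannot be read, and both of these floors are set by a limit, so the true size of each step stays unknown: the limit of > 30000 nM in this assay, at which 2 of the 4 values shown sit.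

Within the compounds shown, neither the aryl group on the amine nitrogen nor the methoxy group on the aromatic carbon yet separates one compound from another in this assay. Still open, on these data alone, is whether a different group on the amine nitrogen, such as a carboxylic acid, a morpholine or a longer alkyl chain, would move the number beyond the scatter, and whether the group on the core can do so at all.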